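A few compounds are considered here, and "the series" means these few. Any claim that something is new, unique, unknown or untested is made for them only; others in the source may bear on it.

Measured compounds:
Compound 1 `O=c1oc2ccc(Cl)cc2c(O)c1C(c1cccc([N+](=O)[O-])c1)c1c(O)c2cc(Cl)ccc2oc1=O` gives 27100 nM in an assay on isolated protein for inhibition of Maltase-glucoamylase (Homo sapiens); on this read-out higher numbers stand for weaker inhibition and lower numbers for stronger inhibition.
Compound 2 `COc1cc(C(c2c(O)c3cc(Cl)ccc3oc2=O)c2c(O)c3cc(Cl)ccc3oc2=O)cc(OC)c1OC` gives 128000 nM in this assay.

Within the data shown here, compound 2 stands at the highest of the two numbers, the weaker of the two measured inhibitions; the only other measured compound is compound 1, which sits lower, and the single measured step runs a 4.7-fold higher number from compound 1 to compound 2 (0.67 log units; beyond the scatter). Compound 3 `COc1ccc(C(c2c(O)c3cc(Cl)ccc3oc2=O)c2c(O)c3cc(Cl)ccc3oc2=O)cc1OC` has not yet been measured. It differs from compound 2 in one place: hydrogen in place of methoxy on an aromatic carbon. Among the measured compounds shown here, no measured step involves the removal of a single methoxy group from an aromatic ring, so nothing directly indicates the direction of this change. The step from compound 1 to compound 2 exchanged the whole aromatic group and is of limited use here. Compound 3 is therefore expected to stay close to compound 2, with the step estimated as a 1.3-fold lower number from compound 2 to compound 3 (0.11 log units; within the scatter), within the scatter. The estimate for compound 3 is 100000 nM, with a range from 40000 nM to 300000 nM.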

Compound 3, half-maximal inhibitory concentration: 91400 nM
Beside the measured number, compound 3's estimate is 1.1-fold (0.04 log units) above it; the measured number falls inside the stated range.
By their numbers in this assay, from the lowest: compound 1; then compounds 3 and 2 (each within the scatter of the next).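

Removing one methoxy group from the aromatic ring gives a 1.4-fold lower number from compound 2 to compound 3 (0.15 log units; within the scatter) in this assay, so this single change, unlike the earlier exchange of the whole aromatic group, does not separate 3,4,5-trimethoxyphenyl from 3,4-dimethoxyphenyl on this read-out. The 3-nitrophenyl group of compound 1 still stands apart from the group with one methoxy fewer, with a 3.4-fold higher number from compound 1 to compound 3 (0.53 log units; beyond the scatter), so the gap seen earlier does not depend on this one methoxy group. No measurement at hand explains either step.

The compounds shown leave open how an amine or a carboxylic acid on this aromatic carbon would read. They also leave open whether removing the remaining methoxy groups, down to a plain phenyl ring, would stay within the scatter as well.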